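This account rests on a few compounds, and the source may have more. Where it says the series, first, only, none or still open, it means among the compounds named here.

In a functional assay on MOLT-4 cells (Homo sapiens) for inhibition, read by sulforhodamine B assay, with a stated time of 48 h, tested at 10 uM (on this read-out lower numbers stand for less inhibition of growth and higher numbers for more inhibition of growth at the one concentration tested), three compounds give a first picture. Compound 1 (`COc1ccc(-c2nc3sc(-c4ccccc4)cn3n2)cc1`) gives 49%, and compound 2 (`COc1cc(-c2nc3sc(-c4ccccc4)cn3n2)cc(OC)c1OC`) gives 44%, so these two lie within the usual scatter of each other. Compound 3 (`C/C(=N/O)c1ccc(NC(=O)Cn2nc(-c3ccccc3)nc2N)cc1`), built quite differently, gives 11.5%, a gap beyond the scatter from both of the others. Compound 1 therefore stands level with compound 2 and clearly above compound 3, with partial growth inhibition at the one concentration tested and room to move either way.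

The next compound, compound 4 (`COc1ccc(-c2nc3sc(-c4ccc(Cl)cc4)cn3n2)cc1`), keeps the core of compound 1 and changes one place: chloro in place of hydrogen on an aromatic carbon. In words, this is chloro in place of hydrogen on an aromatic carbon, which turns phenyl to 4-chlorophenyl. Among the measured compounds shown here, no measured pair in this small set shows this change, so nothing here fixes its size or direction. The expectation in this assay therefore starts from compound 1 at 49% and allows for no shift beyond the scatter. The estimated step is small and upward, a number 3 percentage points higher from compound 1 to compound 4 (within the scatter). Compound 4 is expected to give about 52%, with an estimated range from 35% to 68%.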

Compound 4, percent growth inhibition at one concentration: 17.4%
For compound 4 the middle estimate is 34.6 percentage points above the measured one, outside the stated range (below it).
By their numbers in this assay, from the lowest: compounds 3 and 4 (each within the scatter of the next); then compounds 2 and 1 (each within the scatter of the next).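

This position on the phenyl ring is not a free place to add to: in this assay, the step is large and beyond the scatter, a number 31.6 percentage points lower from compound 1 to compound 4 (beyond the scatter). The change is as small as a change of group can be, with one chlorine atom replacing a hydrogen on an aromatic carbon, para to a large group, and it adds no ring, no hydrogen-bond donor or acceptor and no net charge, so even a single heavy atom at this carbon can carry a large loss of growth inhibition. Nothing at hand explains why this swap matters so much, so the result stands as an observation without a cause.

A single substituent cannot show whether the loss belongs to chloro itself or would follow any group at this carbon, and a fluoro, a methoxy or an amine in the same place would begin to separate those two readings. Going by these compounds, it also remains open whether a chloro at another carbon of this phenyl ring, or the same 4-chlorophenyl on the core of compound 2, would bring a step of similar size.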